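A few compounds are considered here, and "the series" means these few. Any claim that something is new, unique, unknown or untested is made for them only; others in the source may bear on it.

Of the compounds shown here, two sharing one core have been measured in a functional assay on Bel7402/5-FU cells (Homo sapiens) for antiproliferative activity, read by MTT assay, with a stated time of 72 h; a lower number here means a stronger inhibitor, a higher number a weaker inhibitor. Compound 1 `C=C1C(=O)O[C@H]2[C@H]1CC/C(COC(=O)CCC(=O)N1CCN(C(=O)Cn3cc(F)c(=O)[nH]c3=O)CC1)=C\CC[C@@]1(C)O[C@@H]21` gives no number in this assay but only a limit, > 20000 nM, which is the limit of > 20000 nM in this assay, at which 1 of the 2 values shown sits. Among the measured compounds shown here, compound 2 `C=C1C(=O)O[C@H]2[C@H]1CC/C(COC(=O)Cn1cc(F)c(=O)n(Cc3ccc(Br)cc3)c1=O)=C\CC[C@@]1(C)O[C@@H]21` gives 3240 nM in this assay, the only plain number among the two values shown. Compound 3 `C=C1C(=O)O[C@H]2[C@H]1CC/C(COC(=O)Cn1cc(F)c(=O)n(C)c1=O)=C\CC[C@@]1(C)O[C@@H]21` has not yet been measured; it differs from compound 2 by hydrogen in place of 4-bromophenyl on a saturated chain carbon bound to an aromatic nitrogen. For the measured compounds named here, no step between measured compounds that differ in a single place is available, so the size of the change from compound 2 to compound 3 in this assay cannot be read off a neighbouring pair and has to be expected rather than derived. Compound 3 is expected to come out somewhat weaker than compound 2 in this assay, by a step of a 2.2-fold higher number from compound 2 to compound 3 (0.33 log units; beyond the scatter), with a real chance that only a limit is reported. For compound 3 the estimate in this assay is 7000 nM, within a range from 2000 nM to 25000 nM.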

Compound 3, half-maximal inhibitory concentration: 11700 nM
For compound 3 the middle estimate is 1.7-fold (0.22 log units) below the measured one; the measured number falls inside the stated range.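

In this assay, among the compounds shown here, replacing 4-bromobenzyl with methyl on the aromatic nitrogen gives a 3.6-fold higher number from compound 2 to compound 3 (0.56 log units; beyond the scatter), the first step that can be read at this position. The step lies beyond the scatter but is modest, so compound 3 still gives a plain number without the 4-bromophenyl ring, and the ring is not required for a measurable effect on these cells. Compound 1 gives only a limit, and no step to it can be read: the limit of > 20000 nM in this assay, at which 1 of the 3 values shown sits.

The compounds shown leave open whether the difference rests with the bromine or with the ring itself, a question that a plain benzyl group on the same nitrogen would separate. They also leave open how a longer chain such as butyl, or one ending in an amine, would compare with methyl at this position.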